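The compounds below may be only part of what the source reports. "The series", "measured", "known", "first", "only" and "open" are said of these compounds alone.

Series notes. Compound 1 `COc1cccc(S(=O)(=O)c2ccc(CN/C(=N\C#N)Nc3ccncc3)cc2)c1` gives 1.9 nM in an assay on isolated protein for inhibition of Nicotinamide phosphoribosyltransferase (Homo sapiens), read by mass spectrometry, with stated times of 15 min and 30 min; on this read-out higher numbers stand for weaker inhibition and lower numbers for stronger inhibition. Compound 2 `N#C/N=C(\NCc1ccc(S(=O)(=O)c2ccccc2)cc1)Nc1ccncc1` gives 2.5 nM in this assay, and compound 3 `N#C/N=C(\NCc1ccc(S(=O)(=O)N2CC3CCC(C2)O3)cc1)Nc1ccncc1` gives 2.4 nM in this assay. The three numbers sit close together: a 1.3-fold higher number from compound 1 to compound 3 (0.10 log units; within the scatter), and a 1.0-fold lower number from compound 2 to compound 3 (0.02 log units; within the scatter). Compound 3 therefore stands alongside the other two with no separation beyond the scatter.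

Compound 4 `N#C/N=C(\NCc1ccc(S(=O)(=O)c2cccc3cccnc23)cc1)Nc1ccncc1` differs from compound 3 in one place: a group of 10 heavy atoms (9 carbon, 1 nitrogen; one six-membered aromatic ring of carbon only, one six-membered aromatic ring with 1 hetero atom) in place of a group of 8 heavy atoms (6 carbon, 1 nitrogen, 1 oxygen; one five-membered non-aromatic ring with 1 hetero atom, one six-membered non-aromatic ring with 2 hetero atoms), on a sulfonyl sulfur. The measured steps that bear on this position are the exchanges at the sulfonyl sulfur, a 1.3-fold higher number from compound 1 to compound 3 (0.10 log units; within the scatter) and a 1.0-fold lower number from compound 2 to compound 3 (0.02 log units; within the scatter), and both left the number essentially where it was. The quinolin-8-yl group returns an aromatic ring to the sulfonyl sulfur, as carried by compound 1 and compound 2, whose numbers match that of compound 3. Nothing in the three measured compounds suggests a shift on this exchange, so the expected step is a 1.0-fold higher number from compound 3 to compound 4 (0.02 log units; within the scatter), with no movement beyond the scatter. Compound 4 is estimated at 2.5 nM in this assay, between 1 nM and 7 nM.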

Compound 4, half-maximal inhibitory concentration: 3.6 nM
Compound 4: middle estimate off by 1.4-fold (0.16 log units), on the low side; measured number inside the range.
By their numbers in this assay, from the lowest: compounds 1, 3, 2 and 4 (each within the scatter of the next).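

Quinolin-8-yl on the sulfonyl sulfur extends the range of groups accepted there in this assay to a two-ring aromatic group, and no exchange moves the number beyond the scatter: quinolin-8-yl in place of phenyl gives (a 1.4-fold higher number from compound 2 to compound 4 (0.16 log units; within the scatter)), quinolin-8-yl in place of 3-methoxyphenyl gives (a 1.9-fold higher number from compound 1 to compound 4 (0.28 log units; within the scatter)), and the exchange for the non-aromatic bridged group gives (a 1.5-fold higher number from compound 3 to compound 4 (0.18 log units; within the scatter)). All four compounds therefore remain within the scatter at this position, with none going against that reading. No measurement here accounts for this flat response.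

The compounds shown leave open whether any group on the sulfonyl sulfur moves the number beyond the scatter. On these data alone, a carboxylic acid or an open-chain amine at this place would test that, while the rest of the shared core remains unexplored here.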